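The compounds below may be only part of what the source reports. "The series", "measured", "known", "first", "only" and "open" are said of these compounds alone.

Among the compounds with values here, in a functional assay on MCF7 cells (Homo sapiens) for cytotoxicity, read by MTT assay, with a stated time of 48 h (a higher number here means a weaker inhibitor, a lower number a stronger inhibitor), compound 1 `CC(=NNC(=S)Nc1ccccc1F)c1ccccn1` gives 0.39 nM, second highest of the three numbers so far. Compound 3 `CC(=NNC(=S)Nc1ccccc1)c1ccccn1` gives 0.18 nM, and compound 2 `CC(=NNC(=S)Nc1ccccc1[N+](=O)[O-])c1ccccn1` gives 5.7 nM. Compound 4 `C/C(=N\NC(=S)Nc1ccccc1F)c1ccccn1` is now to be compared with compound 1. The change is the two compounds have the same atoms and bonds; at least one stereo element is drawn with a configuration in one of them and without one in the other: 1 of 1 stereo elements differ; a double bond is drawn without a configuration in compound 1 and E in compound 4: the same atoms and bonds, with a double bond drawn without a configuration in compound 1 and E in compound 4. Within the data shown here, no measured step tests a configuration. All three replace a group on an aromatic carbon: a 2.2-fold lower number from compound 1 to compound 3 (0.34 log units; beyond the scatter), a 15-fold higher number from compound 1 to compound 2 (1.16 log units; beyond the scatter) and a 32-fold lower number from compound 2 to compound 3 (1.50 log units; beyond the scatter). No such replacement occurs here, so these steps set no size for this comparison. The undrawn configuration of compound 1 leaves open whether the two drawings describe the same material. No step beyond the scatter is therefore expected in this assay, and no direction is favoured. The estimated step is no change at the digits printed from compound 1 to compound 4 (within the scatter). For compound 4 the expected value is 0.39 nM, with an estimated range of 0.15 nM to 1 nM.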

Compound 4, half-maximal inhibitory concentration: 0.39 nM
Compound 4: middle estimate and measured number agree at the digits printed; low and high end bracket the measured number.
By their numbers in this assay, from the lowest: compound 3; then compounds 1 and 4 (each within the scatter of the next); then compound 2.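

In this assay, within the data shown here, the first comparison that leaves every atom and bond unchanged gives no change at the digits printed from compound 1 to compound 4 (within the scatter). The fluoro group stays in place, and the only difference is that the double bond is drawn E in compound 4 and without a configuration in compound 1. This step cannot be read as a measured effect of E against another configuration, because the comparison rests on a difference in drawing alone: the fact that one of compounds 1 and 4 is drawn with a defined configuration and the other without, at the place where they differ

Going by these compounds, a double bond drawn Z remains open, so the series offers no comparison between two defined configurations. Also open, on these data alone, is how a methoxy group or an amine in place of fluoro on the aromatic carbon would compare with compound 1.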